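The compounds below may be only part of what the source reports. "The series", "measured", "known", "first", "only" and "open" are said of these compounds alone.

Working notes on the series in a functional assay on cells (leukaemia cell line, Homo sapiens) for inhibition, read by sulforhodamine B assay, with a stated time of 48 h; on this read-out higher numbers stand for weaker inhibition of growth and lower numbers for stronger inhibition of growth. Compound 1 `O=S(=O)(Nc1ccc(F)c(Cl)c1)c1ccc(-c2cnc(C3CC3)o2)cc1` gives 260 nM, compound 2 `Cc1cc(NS(=O)(=O)c2ccc(-c3cnc(C4CC4)o3)cc2)ccc1Cl` gives 216 nM, and compound 3 `Cc1ccc(NS(=O)(=O)c2ccc(-c3cnc(C4CC4)o3)cc2)cc1C` gives 420 nM. Compound 3 therefore stands within the scatter of both others, and no order can be read among the three.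

The next step leads to compound 4 `O=S(=O)(Nc1ccc(F)cc1F)c1ccc(-c2cnc(C3CC3)o2)cc1`: 2,4-difluorophenyl in place of 3,4-dimethylphenyl on a sulfonamide nitrogen. The measured changes at this group are a 1.2-fold lower number from compound 1 to compound 2 (0.08 log units; within the scatter), a 1.6-fold higher number from compound 1 to compound 3 (0.21 log units; within the scatter) and a 1.9-fold higher number from compound 2 to compound 3 (0.29 log units; within the scatter). For the measured compounds named here, none leaves the scatter, but no measured compound carries 2,4-difluorophenyl. No step beyond the scatter is expected, and no direction is favoured. The expected step is a 1.1-fold lower number from compound 3 to compound 4 (0.02 log units; within the scatter). For compound 4 the estimated value is 400 nM, with an expected range of 160 nM to 1000 nM.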

Compound 4, concentration for 50% growth inhibition: 356 nM
Beside the measured number, compound 4's estimate is 1.1-fold (0.05 log units) above it; the range from low to high includes it.
By their numbers in this assay, from the lowest: compounds 2, 1, 4 and 3 (each within the scatter of the next).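

For the compounds shown here, with 2,4-difluorophenyl on the sulfonamide nitrogen, the first group here whose only substituents are fluorine, the steps are a 1.2-fold lower number from compound 3 to compound 4 (0.07 log units; within the scatter) and a 1.6-fold higher number from compound 2 to compound 4 (0.22 log units; within the scatter) and a 1.4-fold higher number from compound 1 to compound 4 (0.14 log units; within the scatter) and none leaves the scatter. This place thus accepts an all-fluorine, an all-methyl and two chlorine-bearing phenyl groups without a readable order among the four compounds. No measurement available here accounts for how closely these values lie.

From the compounds shown here alone, whether an unsubstituted phenyl, a pyridine or an aminophenyl would leave the scatter remains open. So does the effect of a carboxylic acid on the phenyl ring or a longer chain in its place.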